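Amide variations on a chalcone series: inhibition at fixed concentration

A few compounds are considered here, and "the series" means these few. Any claim that something is new, unique, unknown or untested is made for them only; others in the source may bear on it.

Measured compounds and values in a functional assay on HUVEC cells (Homo sapiens) for inhibition, tested at 5 ug/mL; a lower number here means a weaker effect, a higher number a stronger effect of the compound at the concentration tested:
- compound 1 `COc1cc(/C=C/C(=O)c2cccc(NC(=O)c3c(Cl)cccc3Cl)c2)ccc1O`: 88%
- compound 2 `COc1cc(/C=C/C(=O)c2cccc(NC(=O)c3cccs3)c2)ccc1O`: 80%
- compound 3 `COc1cc(/C=C/C(=O)c2cccc(NC(=O)c3ccco3)c2)ccc1O`: 82%

Compound 2 holds the lowest of the three numbers. Its nearest neighbour is compound 3, with a number 2 percentage points higher from compound 2 to compound 3 (within the scatter), and the furthest is compound 1, with a number 8 percentage points lower from compound 1 to compound 2 (within the scatter); both steps lie within the scatter, so no order among the three is established.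

Compound 4 `COc1cc(/C=C/C(=O)c2cccc(NC(=O)c3ccc(Cl)cc3Cl)c2)ccc1O` is not yet measured. The change from compound 2 is 2,4-dichlorophenyl in place of thiophen-2-yl on a carbonyl carbon. Among the compounds with values here, the step that bears most on it is the one between compound 1 and compound 2, since compound 1 also carries a dichlorophenyl on the carbonyl carbon: a number 8 percentage points lower from compound 1 to compound 2 (within the scatter). The step from compound 1 to compound 3, a number 6 percentage points lower from compound 1 to compound 3 (within the scatter), points the same way, also within the scatter. A six-membered carbon ring with two chlorines in place of the five-membered ring is therefore expected to give a number on the side of compound 1, with an expected step of a number 6 percentage points higher from compound 2 to compound 4 (within the scatter), not beyond the scatter. Compound 4 is estimated at 86%, in the range 74% to 95%.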

Compound 4, a percentage reported as inhibition, at one concentration (the size of the read-out at that concentration, not a potency): 51%
Estimate against measurement, compound 4: 35 percentage points above; measured number below the stated range.
By their numbers in this assay, from the lowest: compound 4; then compounds 2, 3 and 1 (each within the scatter of the next).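

In this assay, the group on the amide carbonyl carbon had not yet separated the compounds, since thiophen-2-yl, furan-2-yl and 2,6-dichlorophenyl stay within the scatter of one another, but 2,4-dichlorophenyl shows that this place can respond, with a number 29 percentage points lower from compound 2 to compound 4 (beyond the scatter) and a number 31 percentage points lower from compound 3 to compound 4 (beyond the scatter). The clearest reading comes from the two dichlorophenyl groups, which share the same six-membered carbon ring and the same two chlorines and differ only in the arrangement of those chlorines, yet give a number 37 percentage points lower from compound 1 to compound 4 (beyond the scatter), so the ring and its chlorine count do not by themselves keep the number high in this small set. No measurement at hand accounts for this drop.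

Still open, going by these compounds, is whether the lower number is peculiar to the 2,4-dichlorophenyl arrangement or would also appear with other groups on this carbonyl carbon, such as a plain phenyl or an aminophenyl. With each compound read at one concentration, the size of the drop also leaves the potency of compound 4 relative to the others undefined.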